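Amide cap variation on the chlorophenylpiperidine valine series

The source may report more compounds than this note shows. Statements on the series, on what has been measured and on what is new or still open speak of the compounds shown alone.

compound 1 `CC(C)[C@@H](NC(=O)CCc1ccc(F)cc1)C(=O)N1CCC(c2ccc(Cl)cc2)CC1` — 70 nM
compound 2 `CC(C)[C@@H](NC(=O)CCCc1ccccc1)C(=O)N1CCC(c2ccc(Cl)cc2)CC1` — 95 nM
compound 3 `CC(C)[C@@H](NC(=O)NCc1ccccc1)C(=O)N1CCC(c2ccc(Cl)cc2)CC1` — 180 nM

In an assay on THP-1 cells for displacement of a labelled ligand from C-C chemokine receptor type 1 (Homo sapiens) (a lower number here means a stronger inhibitor, a higher number a weaker inhibitor), compound 3 gives the highest of the three numbers: a 1.9-fold higher number from compound 2 to compound 3 (0.28 log units; within the scatter) and a 2.6-fold higher number from compound 1 to compound 3 (0.41 log units; beyond the scatter). Compound 4 `CC(C)[C@@H](NC(=O)c1cc2ccccc2s1)C(=O)N1CCC(c2ccc(Cl)cc2)CC1` differs from compound 3 by 1-benzothiophen-2-yl in place of benzylamino on a carbonyl carbon. Among the measured compounds shown here, no measured step covers this exchange directly; the only bearing comes from the two steps just named, which put the benzylamino cap at the weaker end of the set and the carbon-linked aryl caps at the other. On that basis, and with wide uncertainty, a modest decrease in the this assay number is expected for compound 4. Compound 4 is estimated at 60 nM, range 15 nM to 250 nM, which is expected to mean a step of a 3.0-fold lower number from compound 3 to compound 4 (0.48 log units; beyond the scatter).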

Compound 4, half-maximal inhibitory concentration: 58 nM
Beside the measured number, compound 4's estimate is 1.0-fold (0.01 log units) above it; low and high end bracket the measured number.
By their numbers in this assay, from the lowest: compounds 4, 1, 2 and 3 (each within the scatter of the next, the first and the last beyond it).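

Attached directly to the carbonyl carbon, with no chain, 1-benzothiophen-2-yl reads level with both chain caps in this assay (a 1.6-fold lower number from compound 2 to compound 4 (0.21 log units; within the scatter)) and (a 1.2-fold lower number from compound 1 to compound 4 (0.08 log units; within the scatter)). Only the benzylamino cap stands apart (a 3.1-fold lower number from compound 3 to compound 4 (0.49 log units; beyond the scatter)), and that exchange also removes a hydrogen-bond donor from the cap. Nothing available accounts for this difference. Still open, from the compounds shown here alone, is how an amine or a carboxylic acid on the 1-benzothiophen-2-yl cap would read. Going by these compounds, a plain phenyl on the same carbonyl carbon is equally open.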